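Bromine Enters the Amide Series at a New Position

The source may report more compounds than this note shows. Statements on the series, on what has been measured and on what is new or still open speak of the compounds shown alone.

Compound 1 `O=C(Nc1cc(-c2ccccc2)nn1-c1ccccc1)c1ccccc1` is the parent amide of this set. In a functional assay on cells for positive allosteric modulation of metabotropic glutamate receptor 5 (Rattus norvegicus), read by calcium flux (on this read-out lower numbers stand for an effect already at smaller amounts and higher numbers for an effect only at larger amounts of compound), compound 1 gives 203 nM, the second highest of the three numbers recorded so far. Compound 2 `O=C(Nc1cc(-c2ccccc2)nn1-c1ccccc1)c1ccc(Cl)c(Cl)c1` gives 13 nM in this assay, and compound 3 `COc1cccc(-c2cc(NC(=O)c3ccccc3)n(-c3ccccc3)n2)c1` gives 600 nM. The two measured steps away from compound 1 run in opposite directions: a 16-fold lower number from compound 1 to compound 2 (1.19 log units; beyond the scatter), whereas a 3.0-fold higher number from compound 1 to compound 3 (0.47 log units; beyond the scatter).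

Compound 4 `O=C(Nc1cc(-c2ccccc2)nn1-c1ccccc1Br)c1ccccc1` differs from compound 1 by bromo in place of hydrogen on an aromatic carbon. Neither measured step touches the same ring: compound 2 carries its halogens on the carbonyl-bearing ring, and compound 3 carries its methoxy on the other phenyl, so the change to compound 4 stands without a direct precedent. A halogen elsewhere gave a large gain in compound 2, but that result cannot simply be transferred to a single bromine placed on a different ring. The expectation is therefore a number close to that of compound 1, with no step beyond the scatter, which for compound 4 means an expected 1.0-fold lower number from compound 1 to compound 4 (0.01 log units; within the scatter) in this assay. Compound 4 is estimated at 200 nM, with a range from 50 nM to 800 nM.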

Compound 4, half-maximal effective concentration: 200 nM
Beside the measured number, compound 4's estimate shows no gap at the digits printed; low and high end bracket the measured number.
By their numbers in this assay, from the lowest: compound 2; then compounds 4 and 1 (each within the scatter of the next); then compound 3.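

In this assay, the change from phenyl to 2-bromophenyl gives a 1.0-fold lower number from compound 1 to compound 4 (0.01 log units; within the scatter) and so cannot be told from the scatter, even though a heavy atom enters on an aromatic carbon, ortho to a large group. The earlier steps shown here concerned other places in the core of compound 1 and both lay beyond the scatter, with a 16-fold lower number from compound 1 to compound 2 (1.19 log units; beyond the scatter) and a 3.0-fold higher number from compound 1 to compound 3 (0.47 log units; beyond the scatter) as their sizes, so compound 4 gives the first case in this set of a substitution that leaves the two numbers indistinguishable. Nothing available here accounts for this outcome at this place.

As far as these compounds go, whether the same holds for a fluoro, a methyl or an amine at this place remains open, as does the outcome for a bromo on the other carbons of this ring. Also open, from the compounds shown here alone, is whether the 2-bromophenyl change would read the same when combined with the 3,4-dichlorophenyl group of compound 2.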